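This account rests on a few compounds, and the source may have more. Where it says the series, first, only, none or still open, it means among the compounds named here.

In a functional assay on K562 cells (Homo sapiens) for inhibition, read by trypan blue exclusion, with a stated time of 72 h (on this read-out higher numbers stand for weaker inhibition and lower numbers for stronger inhibition), compound 1 (`Cn1c(=O)c(S(=O)(=O)c2ccc(F)cc2F)cc2cnc(Nc3ccc4sccc4c3)nc21`) gives 500 nM and compound 2 (`COc1ccc(S(=O)(=O)c2cc3cnc(Nc4ccc5[nH]ccc5c4)nc3n(C)c2=O)cc1`) gives 300 nM so the two values lie within the scatter of each other and neither compound can be ranked above the other. Compound 3 (`Cn1c(=O)c(S(=O)(=O)c2ccc(F)cc2F)cc2cnc(Nc3ccccn3)nc21`) differs from compound 1 in one place only (pyridin-2-yl in place of 1-benzothiophen-5-yl on a nitrogen on an aromatic ring) as its (1-benzothiophen-5-yl)amino group becomes (pyridin-2-yl)amino. For the measured compounds named here, no measured pair of compounds shows a change at this nitrogen, so the data offer no direct guide to its size. The expectation therefore rests on the structural change alone: the entering group is the smaller one, and it is not expected to hold the 500 nM of compound 1 in this assay. The expected change is a 4.0-fold higher number from compound 1 to compound 3 (0.60 log units; beyond the scatter) in the direction of weaker inhibition and beyond the scatter. For compound 3 the estimated value is 2000 nM within an expected range of 600 nM to 8000 nM in this measurement.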

Compound 3, half-maximal inhibitory concentration: 35000 nM
For compound 3 the middle estimate is 18-fold (1.24 log units) below the measured one; the whole stated range lies below it.
By their numbers in this assay, from the lowest: compounds 2 and 1 (each within the scatter of the next); then compound 3.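

In this assay, the group on this nitrogen turns out to matter greatly: pyridin-2-yl in place of 1-benzothiophen-5-yl gives a 70-fold higher number from compound 1 to compound 3 (1.85 log units; beyond the scatter), a large step towards weaker inhibition. The earlier compounds shown here offered no pair that changed at this nitrogen, and this step now shows that a single change here, with the rest of compound 1 kept, can take inhibition far outside the scatter. Nothing available explains why the step is so large.

As far as these compounds go, what stays open is whether the loss goes with giving up the second ring of 1-benzothiophen-5-yl or with the ring nitrogen of pyridin-2-yl. A phenyl group or a pyridin-3-yl group on the same nitrogen would help to separate these two readings.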